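Methoxy addition on the aryl ring of compound 1

The source may report more compounds than this note shows. Statements on the series, on what has been measured and on what is new or still open speak of the compounds shown alone.

Of the compounds shown here, two have been measured. Compound 1 `COc1ccc(-c2cc(/C=C/C(=O)c3ccc(N)cc3)[nH]n2)cc1` in a functional assay on HCC 2998 cells (Homo sapiens) for inhibition, read by sulforhodamine B assay, with a stated time of 48 h (on this read-out higher numbers stand for weaker inhibition of growth and lower numbers for stronger inhibition of growth), gives 1830 nM. Compound 2 `COc1cc(-c2cc(/C=C/C(=O)c3ccc(F)c(F)c3)[nH]n2)cc(OC)c1OC` in this assay gives 3690 nM; the gap between compound 1 and compound 2 lies within the scatter, so compound 1 cannot be set apart from compound 2 on these numbers. Compound 3 `COc1ccc(-c2cc(/C=C/C(=O)c3ccc(N)cc3)[nH]n2)cc1OC` is the next candidate. Relative to compound 1 it differs by methoxy in place of hydrogen on an aromatic carbon, the new group sitting ortho to a methoxy group and meta to a large group. Among the measured compounds shown here, no pair of measured compounds isolates this change, so its size in this assay can only be judged from the structures. No shift beyond the scatter is expected for the step of a 1.1-fold higher number from compound 1 to compound 3 (0.04 log units; within the scatter). Compound 3 is estimated at 2000 nM, with a range of 700 nM to 6000 nM.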

Compound 3, concentration for 50% growth inhibition: 2020 nM
The estimate for compound 3 lay 1.0-fold (0.00 log units) below the measured number; the range from low to high includes it.
By their numbers in this assay, from the lowest: compounds 1, 3 and 2 (each within the scatter of the next).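

Among the compounds shown here, compound 3 gives the first reading of this change on the core of compound 1: in this assay the step is a 1.1-fold higher number from compound 1 to compound 3 (0.04 log units; within the scatter) for methoxy in place of hydrogen on an aromatic carbon. At this place, ortho to a methoxy group and meta to a large group, the added methoxy leaves compound 3 indistinguishable from compound 1 on this read-out, a comparison that compound 2 could not give, as it differs from compound 1 in more than one place. Nothing available on these compounds offers an explanation for this result.

Open, from the compounds shown here alone, is whether this place accepts groups other than methoxy, such as a hydroxyl, an amine or a longer chain like ethoxy. Also open, going by these compounds, is whether removing the existing methoxy group would shift the number in this assay beyond the scatter.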